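Swapping the ester chain for cyclopentyl on compound 1

The source may report more compounds than this note shows. Statements on the series, on what has been measured and on what is new or still open speak of the compounds shown alone.

Compound 1, `CC(C)(C)OC(=O)CCCN1CCc2c(sc(NC(=O)Nc3ccc(Cl)cc3)c2C(N)=O)C1`, is the starting point of this account. In a functional assay (strain AB) with Danio rerio as the target, read by microscopy, with a stated time of 1 h (a higher number here means that more compound is needed for the effect, a lower number that less compound is needed), compound 1 gives 560 nM, the lowest of the two numbers that were obtained. Its nearest neighbour is compound 2, `CCN1CCc2c(sc(NC(=O)Nc3ccc4ccccc4c3)c2C(N)=O)C1`, which in this assay gives 1780 nM, a higher number that lies beyond the usual scatter. Compound 3, `CCN1CCc2c(ccc(NC(=O)Nc3ccc(Cl)cc3)c2C(N)=O)C1`, carries a different core and in this assay reaches only > 25000 nM, which is a limit of the measurement and not a number; that is the limit of > 25000 nM in this assay, at which 1 of the 3 values shown sits.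

The compound still to be measured is compound 4, `NC(=O)c1c(NC(=O)Nc2ccc(Cl)cc2)sc2c1CCN(CC1CCCC1)C2`. It differs from compound 1 in one place: cyclopentyl in place of 2-(tert-butoxycarbonyl)ethyl on a saturated chain carbon bound to an amine nitrogen in a ring. For the measured compounds named here, no measured pair in this set shows the effect of such a change, so any expectation rests on the single value of compound 1 alone. The author expects a step of a 1.4-fold higher number from compound 1 to compound 4 (0.15 log units; within the scatter), that is, a change of modest size in either direction rather than a clear shift. For compound 4 the estimated value in this assay is 800 nM, with a range from 200 nM to 4000 nM.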

Compound 4, half-maximal effective concentration: 1830 nM
Estimate against measurement, compound 4: 2.3-fold (0.36 log units) below; the range from low to high includes it.
By their numbers in this assay, from the lowest: compound 1; then compounds 2 and 4 (each within the scatter of the next). At a limit, above all of these: compound 3.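

For the compounds shown here, compound 4 gives the first reading of a change at this position, on a saturated chain carbon bound to an amine nitrogen in a ring: in this assay, replacing 2-(tert-butoxycarbonyl)ethyl with cyclopentyl gives a 3.3-fold higher number from compound 1 to compound 4 (0.51 log units; beyond the scatter). The position therefore responds to what it carries, although the step is modest and compound 4 still gives a measured number with no ester in the group. No measurement shown here accounts for the step.

Which part of the change carries the step stays open, whether the loss of the ester or the arrival of the ring. Also unsettled is how a carboxylic acid, a basic amine or a plain longer alkyl chain in the same place would read in this assay.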